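Ring swaps at one carbon and microsomal clearance

The source may hold more compounds than are shown below. What is called first, only, known or untested is meant among the compounds shown, and "the series" means these compounds.

Compound 1 `Nc1ccc(S(=O)(=O)N2CCN(c3ncc(C(O)(C(F)(F)F)C(F)(F)F)cc3Br)CC2)cn1` gives 32 mL.min-1.g-1
Compound 2 `CCn1cc(-c2cc(C(O)(C(F)(F)F)C(F)(F)F)cnc2N2CCN(S(=O)(=O)c3ccc(N)nc3)CC2)cn1` gives 194 mL.min-1.g-1
Compound 3 `Cc1csc(-c2cc(C(O)(C(F)(F)F)C(F)(F)F)cnc2N2CCN(S(=O)(=O)c3ccc(N)nc3)CC2)c1` gives 399 mL.min-1.g-1

In an ADME assay (liver) for metabolic stability, with Liver microsome (Rattus norvegicus) as the target, using microsomes and NADPH, with a stated time of 30 min, tested at 1 uM (a higher number here means faster removal of the compound, a lower number slower removal), compound 3 at 399 mL.min-1.g-1 stands highest of the three numbers. The change to compound 4 `Nc1ccc(S(=O)(=O)N2CCN(c3ncc(C(O)(C(F)(F)F)C(F)(F)F)cc3-c3cccc(F)c3)CC2)cn1` is 3-fluorophenyl in place of 4-methylthiophen-2-yl on an aromatic carbon. Among the measured compounds shown here, no measured step makes this exact swap. Putting a ring in place of bromo at that carbon gave a 6.1-fold higher number from compound 1 to compound 2 (0.78 log units; beyond the scatter) (modest) and a 12-fold higher number from compound 1 to compound 3 (1.10 log units; beyond the scatter) (large). Swapping one ring for another gave a 2.1-fold higher number from compound 2 to compound 3 (0.31 log units; beyond the scatter) (modest), and this is the closest guide. Another ring swap should therefore also be modest. With compound 3 highest so far, a slight fall is expected, giving an estimated step of a 1.4-fold lower number from compound 3 to compound 4 (0.15 log units; within the scatter) in this assay at this carbon. The expected value for compound 4 is 280 mL.min-1.g-1 (estimated range 120 mL.min-1.g-1 to 600 mL.min-1.g-1).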

Compound 4, intrinsic clearance in microsomes: 52 mL.min-1.g-1
Beside the measured number, compound 4's estimate is 5.4-fold (0.73 log units) above it; the whole stated range lies above it.
By their numbers in this assay, from the lowest: compounds 1 and 4 (each within the scatter of the next); then compound 2; then compound 3.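

In this assay, a ring at this carbon need not clearly outrun bromo: 3-fluorophenyl gives a 1.6-fold higher number from compound 1 to compound 4 (0.21 log units; within the scatter), unlike the two earlier rings. The choice of ring matters far more than compound 2 and compound 3 alone suggested, with a 7.7-fold lower number from compound 3 to compound 4 (0.88 log units; beyond the scatter) and a 3.7-fold lower number from compound 2 to compound 4 (0.57 log units; beyond the scatter). Nothing available here explains this gap between the rings. From the compounds shown here alone, it remains open whether the fluorine or the six-membered carbon ring carries the difference. Plain phenyl at this carbon would help separate the two.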